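Methoxy added to the chlorophenyl ring of compound 1

A few compounds are considered here, and "the series" means these few. Any claim that something is new, unique, unknown or untested is made for them only; others in the source may bear on it.

Compound 1 `O=C(O)Cn1c(SCc2cccc(Cl)c2)nc2ccccc21` is the reference point of this pair. In an assay on HEK293 cells for displacement of a labelled ligand from prostaglandin D2 receptor 2 (Homo sapiens) (a higher number here means a weaker inhibitor, a lower number a stronger inhibitor), compound 1 gives 186 nM, the lower of the two numbers recorded so far. Among the measured compounds shown here, compound 2 `Cc1ccccc1CSc1nc2ccccc2n1CC(=O)O` gives 810 nM in this assay, and the one recorded step, a 4.4-fold higher number from compound 1 to compound 2 (0.64 log units; beyond the scatter), shows that exchanging the aryl group on the saturated chain carbon bound to sulfur moves the number by a modest amount. Compound 3 `COc1ccc(Cl)cc1CSc1nc2ccccc2n1CC(=O)O` differs from compound 1 by methoxy in place of hydrogen on an aromatic carbon. For the measured compounds named here, no recorded step concerns an added substituent on an otherwise unchanged ring, so the step from compound 1 to compound 2 is the only guide, and it suggests that changes on this ring stay modest. Compound 3 is therefore expected to land near compound 1, at an estimated 250 nM with a range from 80 nM to 800 nM. The expected step is a 1.3-fold higher number from compound 1 to compound 3 (0.13 log units; within the scatter), with the direction uncertain.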

Compound 3, half-maximal inhibitory concentration: 740 nM
Beside the measured number, compound 3's estimate is 3.0-fold (0.47 log units) below it; low and high end bracket the measured number.
By their numbers in this assay, from the lowest: compound 1; then compounds 3 and 2 (each within the scatter of the next).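

In this assay, methoxy in place of hydrogen on an aromatic carbon of the chlorophenyl ring gives a 4.0-fold higher number from compound 1 to compound 3 (0.60 log units; beyond the scatter) and so shows that this place, ortho to a large group and para to the chloro group, does not take the addition without a weaker result. The earlier step exchanged one aryl group for another, whereas this one keeps the chloro group and shows that adding a single group to the ring is enough for a modest shift. No measurement on hand bears on the reason for this shift.

As far as these compounds go, whether the shift belongs to methoxy itself or to any group at this place stays open, and a fluoro or hydroxyl group here would help separate the two. Also open, from the compounds shown here alone, is how an amine or a longer alkoxy chain would fare on the other ring carbons.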